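The compounds below may be only part of what the source reports. "The series", "measured", "known", "first", "only" and "open" are said of these compounds alone.

Measured compounds:
compound 1, `Cc1nnc(CN)n1-c1ccc(Cl)cc1C(O)c1ccccc1`, 1.6 mg/kg 
compound 2, `Cc1nnc(CN(C)C)n1-c1ccc(Cl)cc1C(=O)c1ccccc1`, 0.5 mg/kg 
compound 3, `Cc1nnc(CN(C)C)n1-c1ccccc1C(=O)c1ccccc1Cl`, 5 mg/kg 

All three were tested in a functional assay on the whole organism (strain CF-1) for inhibition, with Mus musculus as the target; on this read-out lower numbers stand for an effect already at smaller amounts and higher numbers for an effect only at larger amounts of compound. Among them, compound 2 stands at the lowest number, so it acts at the smallest dose. Compound 1 sits next, at a higher dose that lies beyond the usual scatter, and compound 3 lies furthest away, again well beyond the scatter. Each of these compounds differs from the others in more than one place, so no single change can be tied to any of these gaps.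

Compound 4, `CNCc1nnc(C)n1-c1ccc(Cl)cc1C(=O)c1ccccc1`, has not yet been tested in this assay. It differs from compound 2 in one place: hydrogen in place of methyl on an amine nitrogen. For the measured compounds named here, no pair of measured compounds shows this change alone, so no measured step tells how large its effect is. The change is small, and compounds 1 and 2 both carry an amine on a chain and act at low doses, so a step from compound 2 to compound 4 of modest size, toward a somewhat higher dose, is expected, a 2.0-fold higher number from compound 2 to compound 4 (0.30 log units; within the scatter). Compound 4 is estimated at 1 mg/kg, within a range from 0.4 mg/kg to 3 mg/kg.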

Compound 4, dose for half-maximal effect: 0.1 mg/kg
Beside the measured number, compound 4's estimate is 10-fold (1.00 log units) above it; the whole stated range lies above it.
By their numbers in this assay, from the lowest: compound 4; then compound 2; then compound 1; then compound 3.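

Hydrogen in place of methyl on this amine nitrogen is no minor swap: in this assay, the change from dimethylamino to methylamino gives a 5.0-fold lower number from compound 2 to compound 4 (0.70 log units; beyond the scatter). For the compounds shown here, the earlier compounds each differed in more than one place, so only this pair shows that this nitrogen responds on its own to the loss of one methyl group, and that the response is toward effect at a smaller dose. Nothing in the available data explains why the number moves this way.

On these data alone, this remains one step on one core, so it is open whether the same change would act alike on the core of compound 3. As far as these compounds go, it is also open how an ethylamino group at this place would compare with the methylamino group of compound 4.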